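This account rests on a few compounds, and the source may have more. Where it says the series, first, only, none or still open, it means among the compounds named here.

Compound 1 `CNC(=O)c1sc(-c2ccc(Cl)cc2)nc1C(Br)Br` has been tested in an ADME assay on BHK15 cells (Mesocricetus auratus) for inhibition, read by XTT assay, with a stated time of 36 h (a lower number here means a stronger inhibitor of growth, a higher number a weaker inhibitor of growth), where compound 1 gives 74600 nM. Among the two compounds measured so far, compound 1 has the lowest number, so it is the stronger inhibitor of the pair. Its nearest neighbour is compound 2 `CSC(=O)c1sc(-c2ccc(Cl)cc2)nc1C(Br)Br`, in which methylsulfanyl replaces methylamino on a carbonyl carbon; in this assay compound 2 gives 369000 nM, and the step is a 4.9-fold higher number from compound 1 to compound 2 (0.69 log units; beyond the scatter).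

The compound not yet measured, compound 3 `CC(=O)c1sc(-c2ccc(Cl)cc2)nc1C(Br)Br`, differs from compound 1 in one place: methyl in place of methylamino on a carbonyl carbon. Among the measured compounds shown here, as in the change leading to compound 2, the hydrogen-bond donor on the carbonyl carbon is lost, and the only measured step that bears on this, a 4.9-fold higher number from compound 1 to compound 2 (0.69 log units; beyond the scatter), went toward a weaker inhibitor of growth. A step in the same direction and of roughly that size is therefore expected for compound 3 in this assay, namely a 2.9-fold higher number from compound 1 to compound 3 (0.47 log units; beyond the scatter). Compound 3 is estimated at 220000 nM, with a likely range from 70000 nM to 700000 nM.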

Compound 3, concentration for 50% growth inhibition: 83500 nM
Compound 3: middle estimate off by 2.6-fold (0.42 log units), on the high side; low and high end bracket the measured number.
By their numbers in this assay, from the lowest: compounds 1 and 3 (each within the scatter of the next); then compound 2.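

In this assay, methyl in place of methylamino on the carbonyl carbon gives a 1.1-fold higher number from compound 1 to compound 3 (0.05 log units; within the scatter), so compound 1 and compound 3 cannot be told apart, although methylamino carries a hydrogen-bond donor and methyl carries none. Losing that donor therefore does not by itself go with a weaker inhibitor of growth at this position, which the step to compound 2 alone could have suggested. Methyl in place of methylsulfanyl gives a 4.4-fold lower number from compound 2 to compound 3 (0.65 log units; beyond the scatter), which leaves compound 2 as the one that stands apart among these three, and nothing given here explains why methylsulfanyl behaves differently from the other two groups.

The compounds shown leave open how far this tolerance extends, for example whether a longer chain such as ethyl, a dimethylamino group or a carboxylic acid on the same carbonyl carbon would stay level with compound 1 or move like compound 2. They also leave open whether a methoxy group, with oxygen where compound 2 has sulfur, would follow compound 2 or stay with compound 1 and compound 3.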